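Thiophene exchange on the piperidinylphenyl series: cytotoxicity notes

A few compounds are considered here, and "the series" means these few. Any claim that something is new, unique, unknown or untested is made for them only; others in the source may bear on it.

Measured so far in an ADME assay on CCRF-CEM cells (Homo sapiens) for cytotoxicity, with a stated time of 5 days; a lower number here means a stronger inhibitor, a higher number a weaker inhibitor:
compound 1, `Cc1ccsc1C(=O)/C=C/c1ccc(N2CCCCC2)cc1`, 9900 nM
compound 2, `O=C(/C=C/c1ccc(N2CCCCC2)cc1)c1ccc(Cl)s1`, 41500 nM
compound 3, `Cc1csc(C2=NNC(c3ccc(N4CCCCC4)cc3)C2)c1`, 16300 nM

Compound 3 gives the second highest of the three numbers in this assay. Its nearest neighbour is compound 1, and that gap is within the scatter; compound 2 is the furthest, beyond the scatter on the high side. Within the data shown here, the only step between measured compounds that differ in one place is a 4.2-fold higher number from compound 1 to compound 2 (0.62 log units; beyond the scatter), a chlorinated thiophene in place of a methylated one on a carbonyl carbon.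

Compound 4, `Clc1cc(C2=NNC(c3ccc(N4CCCCC4)cc3)C2)c(Cl)s1`, is the next unmeasured member: 2,5-dichlorothiophen-3-yl in place of 4-methylthiophen-2-yl on a carbon with a double bond to nitrogen. The change is not identical to the measured one; the group names show two chlorines rather than one and a differently attached thiophene, and the core is that of compound 3 rather than compound 1. Even so, a rise in the number of modest size is expected because a 4.2-fold higher number from compound 1 to compound 2 (0.62 log units; beyond the scatter) is the only comparable step and it went in that direction, with wide uncertainty given the different core. For compound 4 the expected value in this assay is estimated at 40000 nM, with a range from 12000 nM to 130000 nM. The expected step is a 2.5-fold higher number from compound 3 to compound 4 (0.39 log units; beyond the scatter).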

Compound 4, half-maximal inhibitory concentration: 37700 nM
Estimate against measurement, compound 4: 1.1-fold (0.03 log units) above, and the stated range covers the measured number.
By their numbers in this assay, from the lowest: compounds 1 and 3 (each within the scatter of the next); then compounds 4 and 2 (each within the scatter of the next).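

In this assay, replacing 4-methylthiophen-2-yl with 2,5-dichlorothiophen-3-yl on a carbon with a double bond to nitrogen gives a 2.3-fold higher number from compound 3 to compound 4 (0.36 log units; beyond the scatter), so this position of the five-membered non-aromatic ring with 2 nitrogen responds to the thiophene exchange, and the change gives a weaker inhibitor. Among these compounds, the earlier step, a 4.2-fold higher number from compound 1 to compound 2 (0.62 log units; beyond the scatter), showed a rise only with a thiophene on a carbonyl carbon; a chlorinated thiophene in place of a methylated one has now raised the number on both cores, though the two exchanges are not identical and these are the only two steps available. No measurement here accounts for either rise, so the result stands as an observation only.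

This step changes the substituents on the thiophene and its point of attachment together, so it leaves open how much of the rise belongs to the chlorines and how much to attachment through the 3-position rather than the 2-position. Also open, going by these compounds, is how the number would respond at this carbon to a plain phenyl, or to a thiophene bearing an amine or a carboxylic acid.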